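The compounds below may be only part of what the source reports. "The series", "measured", "known", "first", "only" and "open" are said of these compounds alone.

Measured compounds:

Compound 1, `CCn1c(-c2cnc(C)nc2)nc2c(N[C@H]3CCN(C(=O)N4CC(OC)C4)C3)ncnc21`: 4.8 L/kg
Compound 2, `CCn1c(-c2cnc(C)nc2)nc2c(N[C@H]3CCN(C(=O)c4cocn4)C3)ncnc21`: 6.1 L/kg
Compound 3, `CCn1c(-c2ccc(C(F)(F)F)nc2)nc2c(O[C@H]3CCN(C(=O)N4CC(OC)C4)C3)ncnc21`: 4.2 L/kg

All three were studied in an ADME assay (Rattus norvegicus, strain Wistar Han) for pharmacokinetics; on this read-out lower numbers stand for narrower distribution and higher numbers for wider distribution into tissues. Compound 1 and compound 2 share one core and differ by one change, (1,3-oxazol-4-yl in place of 3-methoxyazetidin-1-yl on a carbonyl carbon). That change gave a 1.3-fold higher number from compound 1 to compound 2 (0.10 log units; within the scatter), so the two values sit within the usual scatter and no real shift can be read from them.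

Compound 3 has a different core; the difference between the two cores is not broken down here. In this assay compound 3 gives 4.2 L/kg, close to compound 1 and within scatter of compound 2 as well.

Compound 4, `CCn1c(-c2ccc(C(F)(F)F)nc2)nc2c(O[C@H]3CCN(C(=O)c4cocn4)C3)ncnc21`, has not yet been measured. It differs from compound 3 by 1,3-oxazol-4-yl in place of 3-methoxyazetidin-1-yl on a carbonyl carbon, the same change already seen between compound 1 and compound 2, at the same place. Because that earlier change gave a 1.3-fold higher number from compound 1 to compound 2 (0.10 log units; within the scatter), a similar, small step is expected here: compound 4 is expected to show a 1.3-fold higher number from compound 3 to compound 4 (0.11 log units; within the scatter). For the measured compounds named here, the estimate for compound 4 is therefore 5.4 L/kg, with a likely range from 3.3 L/kg to 8.8 L/kg, resting on compound 3 and the one earlier instance of this change.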

Compound 4, volume of distribution: 2.6 L/kg
Estimate against measurement, compound 4: 2.1-fold (0.32 log units) above; the whole stated range lies above it.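

On the core of compound 3, 1,3-oxazol-4-yl in place of 3-methoxyazetidin-1-yl on a carbonyl carbon gave a 1.6-fold lower number from compound 3 to compound 4 (0.21 log units; within the scatter) in this assay and so no real shift can be read from this step on its own. Set beside the earlier instance of the same change on the core of compound 1, the two steps do not differ by more than repeat measurements would: the same change on two cores in this assay, a 1.3-fold higher number (0.10 log units; within the scatter) from compound 1 to compound 2 and a 1.6-fold lower number (0.21 log units; within the scatter) from compound 3 to compound 4, 2.1-fold (0.31 log units) apart, within the scatter of two such steps. The change therefore shows no real effect on either core and no real dependence on the core, but two pairs cannot prove that it carries over unchanged, and a true core effect of this small size would stay hidden in the scatter.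

The compounds shown leave open how other groups on this carbonyl carbon would compare, such as a dimethylamino group, a phenyl ring or a carboxylic acid. They also leave open whether the same change would behave alike on a third core.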